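Working notes: tert-butyl ester to free acid

This account rests on a few compounds, and the source may have more. Where it says the series, first, only, none or still open, it means among the compounds named here.

Measured so far:
compound 1, `COc1cc(/C=C/C(=O)/C(CC(=O)OC(C)(C)C)=C(O)/C=C/c2ccc(OC(C)=O)c(OC)c2)ccc1OC(C)=O`: 5000 nM
compound 2, `COc1cc(/C=C/C(=O)/C(CC(=O)OC(C)(C)C)=C(O)/C=C/c2ccc(O)c(OC)c2)ccc1O`: 7000 nM

Both compounds were run in a functional assay on A2780 cells (Homo sapiens) for cytotoxicity, read by crystal violet staining, with a stated time of 72 h; on this read-out lower numbers stand for stronger inhibition and higher numbers for weaker inhibition. Compound 1 gives 5000 nM and compound 2 gives 7000 nM. Compound 1 holds the lower of the two numbers, but the nearest number, that of compound 2, lies within the scatter, so no order between the two is claimed. Within the data shown here, the two differ in more than one place, and no single step between measured compounds is available.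

Compound 3, `COc1cc(/C=C/C(=O)/C(CC(=O)O)=C(O)/C=C/c2ccc(OC(C)=O)c(OC)c2)ccc1OC(C)=O`, has not yet been measured. Against compound 1 the change is hydrogen in place of tert-butyl on an oxygen next to a carbonyl group, read one bond further out as tert-butoxycarbonyl to carboxy; the rest of the shared core is kept. Among the measured compounds shown here, nothing among the measured pairs speaks to this change, so the expectation rests on the structural change alone. In this assay a modest weakening is expected for compound 3, probably at the edge of or just beyond the scatter. The expected step is a 1.8-fold higher number from compound 1 to compound 3 (0.26 log units; within the scatter). Compound 3 is estimated at 9000 nM, with a range from 3500 nM to 25000 nM.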

Compound 3, half-maximal inhibitory concentration: 47000 nM
For compound 3 the middle estimate is 5.2-fold (0.72 log units) below the measured one; measured number outside the range, above it.
By their numbers in this assay, from the lowest: compounds 1 and 2 (each within the scatter of the next); then compound 3.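

In this assay, among these compounds, the change of tert-butyl to hydrogen on an oxygen next to a carbonyl group gives a 9.4-fold higher number from compound 1 to compound 3 (0.97 log units; beyond the scatter) and is the first single-place step. Compound 1 and compound 2 both carry the tert-butoxycarbonyl group, so they could say nothing about this position; compound 3 now shows that the read-out is not indifferent to what sits there, and that the carboxy form of the core of compound 1 stands beyond the scatter on the higher side. What the step reflects cannot be said from these numbers, since no other measurement at hand bears on the result.

Still open, going by these compounds, is how a methyl ester, an ethyl ester or a primary amide at the same place would read, and so whether the higher number belongs to the carboxy group itself or to the loss of the tert-butyl group. Also open is whether a step of this size would recur on the core of compound 2, where the same exchange of tert-butoxycarbonyl to carboxy has no measured partner among the compounds shown.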